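Sulfonyl aryl variation on the shared core: working notes

A few compounds are considered here, and "the series" means these few. Any claim that something is new, unique, unknown or untested is made for them only; others in the source may bear on it.

Measured so far:
- compound 1 `COc1ccc(-c2cc(=O)c3c(OC)cc(OC)cc3n2S(=O)(=O)c2ccc(Cl)cc2)cc1` — in a functional assay on SUP-B15 cells (Homo sapiens) for antiproliferative activity, with a stated time of 72 h (on this read-out higher numbers stand for an effect only at larger amounts of compound and lower numbers for an effect already at smaller amounts), compound 1 gives > 34400 nM, which is a limit of the assay.
- compound 2 `COc1ccc(-c2cc(=O)c3c(OC)cc(OC)cc3n2S(=O)(=O)c2cc(Cl)cc(Cl)c2O)cc1` — in this assay compound 2 gives > 37900 nM, again a limit of the assay and not a number.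

Compound 2 therefore stands at the edge of what this assay reports, as the limit of > 37900 nM in this assay, at which 1 of the 2 values shown sits, shows; the other value in the series is likewise a limit, (the limit of > 34400 nM in this assay, at which 1 of the 2 values shown sits). Going by the values given here, the single measured step, a step that the two limits leave unreadable from compound 1 to compound 2, runs between two limits and its size cannot be read.

The next compound, compound 3 `COc1ccc(-c2cc(=O)c3c(OC)cc(OC)cc3n2S(=O)(=O)c2ccc(C)cc2)cc1`, differs from compound 2 by 4-methylphenyl in place of 3,5-dichloro-2-hydroxyphenyl on a sulfonyl sulfur. Among the compounds with values here, no measured step bears readably on this exchange: both sulfonyl aryl variants seen so far sit at limits, and neither shows the effect within range. On that basis compound 3 is expected to remain at or near the limit as well, with an estimated value of 40000 nM in this assay, spanning 15000 nM to 100000 nM. The implied step that the limit leaves unreadable from compound 2 to compound 3 is expected to be none beyond the scatter.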

Compound 3, half-maximal effective concentration: > 44800 nM
Compound 3: a limit, no number; the forecaster's own chance of this, stated with the estimate: 75%; at least 1.1-fold (0.04 log units) between middle value and limit.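

Compound 1, compound 2 and compound 3 all sit at limits of this assay and give no numbers, so none of the steps among compound 1, compound 2 and compound 3 can be read. The compounds shown leave open whether any sulfonyl aryl group on the shared core gives an effect within the range of this read-out.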